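Trading Trifluoromethoxy for Methylsulfanyl in Compound 4

A few compounds are considered here, and "the series" means these few. Any claim that something is new, unique, unknown or untested is made for them only; others in the source may bear on it.

Going by the values given here, in an assay on SK-N-MC cells for inhibition of Neuropeptide Y receptor type 1 (Homo sapiens) (a higher number here means a weaker inhibitor, a lower number a stronger inhibitor), compound 3 `COC(=O)C1=C(C)N=C(C)/C(=C(/O)OC)C1c1cccc(NC(=O)NCCNC2CCN(c3ccccc3OC(F)(F)F)CC2)c1` gives 25 nM, the second highest of the three numbers known. Compound 1 `COC(=O)C1=C(C)N=C(C)/C(=C(/O)OC)C1c1cccc(NC(=O)NCCNC2CCN(c3ccccc3C(F)(F)F)CC2)c1` gives 31 nM, and compound 2 `COC(=O)C1=C(C)N=C(C)/C(=C(/O)OC)C1c1cccc(NC(=O)NCCNC2CCN(c3ccccc3C#N)CC2)c1` gives 3 nM. The steps are a 1.2-fold lower number from compound 1 to compound 3 (0.09 log units; within the scatter), within the scatter, and an 8.3-fold higher number from compound 2 to compound 3 (0.92 log units; beyond the scatter), beyond it. Compound 4 `COC(=O)C1=C(C)N=C(C)/C(=C(/O)OC)C1c1cccc(NC(=O)NCCNC2CCN(c3ccccc3SC)CC2)c1` differs from compound 3 by methylsulfanyl in place of trifluoromethoxy on an aromatic carbon. Among the compounds with values here, no measured step exchanges these two groups; the two steps that touch the same place, a 1.2-fold lower number from compound 1 to compound 3 (0.09 log units; within the scatter) and a 10-fold lower number from compound 1 to compound 2 (1.01 log units; beyond the scatter), show that a change there can be small or large. Compound 4 is therefore expected to land between those outcomes, with the step of a 1.7-fold lower number from compound 3 to compound 4 (0.22 log units; within the scatter) estimated as a modest lowering. The estimate for compound 4 in this assay is 15 nM, within 4 nM to 50 nM.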

Compound 4, half-maximal inhibitory concentration: 5 nM
Estimate against measurement, compound 4: 3.0-fold (0.48 log units) above; measured number inside the range.
By their numbers in this assay, from the lowest: compounds 2 and 4 (each within the scatter of the next); then compounds 3 and 1 (each within the scatter of the next).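

In this assay, methylsulfanyl on this aromatic carbon gives a 5.0-fold lower number from compound 3 to compound 4 (0.70 log units; beyond the scatter) and a 6.2-fold lower number from compound 1 to compound 4 (0.79 log units; beyond the scatter), whereas a 1.7-fold higher number from compound 2 to compound 4 (0.22 log units; within the scatter) stays level with the cyano compound. Cyano is therefore no longer alone at the low end: the four groups now fall into a cyano and methylsulfanyl pair and a trifluoromethyl and trifluoromethoxy pair. Nothing available explains this division. The compounds shown leave open whether methoxy or a chlorine atom on this carbon would join the lower pair or the higher pair.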